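Trifluoromethoxy for trifluoromethyl on a methylated benzimidazole core

A few compounds are considered here, and "the series" means these few. Any claim that something is new, unique, unknown or untested is made for them only; others in the source may bear on it.

Three terphenyl benzimidazoles have been measured in a functional assay on A549 cells (Homo sapiens) for inhibition, read by sulforhodamine B assay; on this read-out lower numbers stand for stronger inhibition of growth and higher numbers for weaker inhibition of growth. Compound 1, `FC(F)(F)c1ccc(-c2ccc(-c3ccc(-c4nc5ccccc5[nH]4)cc3)cc2)cc1`, gives 36600 nM. Compound 2, `FC(F)(F)Oc1ccc(-c2ccc(-c3ccc(-c4nc5ccccc5[nH]4)cc3)cc2)cc1`, differs from compound 1 by trifluoromethoxy in place of trifluoromethyl on an aromatic carbon, and in this assay compound 2 gives 38000 nM; the step is a 1.0-fold higher number from compound 1 to compound 2 (0.02 log units; within the scatter). Compound 3, `Cc1ccc2[nH]c(-c3ccc(-c4ccc(-c5ccc(C(F)(F)F)cc5)cc4)cc3)nc2c1`, carries the change methyl in place of hydrogen on an aromatic carbon on the core, and in this assay compound 3 gives 3520 nM, the step being a 10-fold lower number from compound 1 to compound 3 (1.02 log units; beyond the scatter).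

Compound 4, `Cc1ccc2[nH]c(-c3ccc(-c4ccc(-c5ccc(OC(F)(F)F)cc5)cc4)cc3)nc2c1`, has not yet been measured. It differs from compound 3 by trifluoromethoxy in place of trifluoromethyl on an aromatic carbon. This is the same change as that from compound 1 to compound 2, made at the same kind of place on the trifluoromethyl-bearing ring, while the core differs as described for compound 3 against compound 1. Among the compounds with values here, the one measured instance of this change, a 1.0-fold higher number from compound 1 to compound 2 (0.02 log units; within the scatter), lies within the scatter, which gives little reason to expect movement when it is made on the core of compound 3. The step expected from this change is a 1.1-fold higher number from compound 3 to compound 4 (0.02 log units; within the scatter), essentially a repeat of what compound 1 and compound 2 show. On that basis compound 4 is expected to give about 3700 nM in this assay, with an estimated range from 1800 nM to 7600 nM, close to the value of compound 3 because 3520 nM is the anchor for this pair.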

Compound 4, concentration for 50% growth inhibition: 3560 nM
Compound 4: the middle estimate sits 1.0-fold (0.02 log units) above what was measured; the range from low to high includes it.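

In this assay, trifluoromethoxy in place of trifluoromethyl on the methylated core gives a 1.0-fold higher number from compound 3 to compound 4 (0.00 log units; within the scatter), and this agrees with the same change on the core of compound 1: the same change on two cores in this assay, a 1.0-fold higher number (0.02 log units; within the scatter) from compound 1 to compound 2 and a 1.0-fold higher number (0.00 log units; within the scatter) from compound 3 to compound 4, 1.0-fold (0.01 log units) apart, within the scatter of two such steps

The methyl step carries over in the same way, with an 11-fold lower number from compound 2 to compound 4 (1.03 log units; beyond the scatter) on the trifluoromethoxy pair, and it matches the step seen on the trifluoromethyl pair: the same change on two cores in this assay, a 10-fold lower number (1.02 log units; beyond the scatter) from compound 1 to compound 3 and an 11-fold lower number (1.03 log units; beyond the scatter) from compound 2 to compound 4, 1.0-fold (0.01 log units) apart, within the scatter of two such steps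

Across these four compounds, each change therefore reads the same whichever form the other place takes, but the two cores differ only by one methyl, so this shows nothing about carrying the trifluoromethoxy change to a core that differs more widely, and the numbers alone offer no explanation for the agreement.

The compounds shown leave open whether a chlorine or a methoxy group in place of the methyl on the core would give a step of similar size, and whether the trifluoromethoxy change would still read the same on such a core. As far as these compounds go, it also remains open whether an amine or a carboxylic acid in place of trifluoromethyl would depart from the two fluorinated groups in this assay.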